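Cyclopentyl for Isopropyl on an Amide Nitrogen

The compounds below may be only part of what the source reports. "The series", "measured", "known", "first", "only" and "open" are said of these compounds alone.

Of the compounds shown here, two sharing one core have been tested so far. In an ADME assay on MT4 cells (Homo sapiens) for cytotoxicity, read by MTT assay (on this read-out lower numbers stand for higher toxicity in this test and higher numbers for lower toxicity in this test), compound 1 `O=C(C1C(=O)N(O)C(=O)c2ccccc21)N1CCCCC1` gives 120000 nM, and compound 2 `CC(C)NC(=O)C1C(=O)N(O)C(=O)c2ccccc21` gives 163000 nM. For the measured compounds named here, the only measured step is a 1.4-fold higher number from compound 1 to compound 2 (0.13 log units; within the scatter), so compound 2 sits within the scatter of compound 1 rather than clearly apart from it. Compound 3 `O=C(NC1CCCC1)C1C(=O)N(O)C(=O)c2ccccc21` is not yet measured; it differs from compound 2 by cyclopentyl in place of isopropyl on an amide-type nitrogen. Going by the values given here, no measured step swaps one such group for another of this kind; the single step known, which exchanged piperidin-1-yl for isopropylamino on a carbonyl carbon, stayed within the scatter. On that basis no move beyond the scatter is expected, and the estimated step is a 1.1-fold lower number from compound 2 to compound 3 (0.04 log units; within the scatter). Compound 3 is therefore expected to give about 150000 nM, with a range from 70000 nM to 350000 nM.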

Compound 3, half-maximal cytotoxic concentration: > 250000 nM
Compound 3: no number, only a limit; the forecaster's own chance of this, stated with the estimate: 15%; middle value at least 1.6-fold (0.22 log units) from the limit.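

In this assay compound 3 gives > 250000 nM, which is a limit of the assay and not a number: the limit of > 250000 nM in this assay, at which 1 of the 3 values shown sits. Cyclopentyl in place of isopropyl on an amide-type nitrogen gives an at least 1.5-fold higher number from compound 2 to compound 3 (0.18 log units; that floor lies within the scatter), so this swap alone does not clearly set the two compounds apart. Cyclopentylamino in place of piperidin-1-yl on a carbonyl carbon gives an at least 2.0-fold higher number from compound 1 to compound 3 (0.31 log units; beyond the scatter), the only step shown that passes the scatter, so a change at this position can shift the read-out towards lower toxicity in this test.

From the compounds shown here alone, how far the true number of compound 3 lies from the other two stays open. Also open, going by these compounds, is what cyclohexyl, a longer chain or a ring carrying an amine would do on this amide-type nitrogen.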